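Pyridyl for tolyl on the amide carbonyl of compound 1

A few compounds are considered here, and "the series" means these few. Any claim that something is new, unique, unknown or untested is made for them only; others in the source may bear on it.

Compound 1 `Cc1ccc(C(=O)Nc2cc(-c3ccccc3)nn2-c2ccccc2)cc1` gives 780 nM in an assay on HEK293 cells for displacement of a labelled ligand from metabotropic glutamate receptor 5 (Rattus norvegicus); on this read-out lower numbers stand for stronger inhibition and higher numbers for weaker inhibition. Among the three measured compounds it stands second highest: compound 2 `O=C(Nc1cc(-c2ccccc2)nn1-c1ccccc1Cl)c1ccccc1` gives 500 nM, a difference within the usual scatter, while compound 3 `N#Cc1ccc(C(=O)N(C(=O)c2ccc(C#N)cc2)c2cc(-c3ccccc3)nn2-c2ccccc2)cc1` gives 3050 nM, a gap beyond the scatter and on the side of weaker inhibition. Compound 4 `Cc1ccc(C(=O)Nc2cc(-c3ccccc3)nn2-c2ccccc2)cn1` has not yet been measured in this assay. It differs from compound 1 in one place: 6-methylpyridin-3-yl in place of 4-methylphenyl on a carbonyl carbon. For the measured compounds named here, no measured pair shows this change, so its size cannot be read from the data at hand. The step of a 1.5-fold higher number from compound 1 to compound 4 (0.19 log units; within the scatter) is expected to be small, toward a higher number, and probably within the scatter. Compound 4 is accordingly expected to give 1200 nM, with a range from 400 nM to 3600 nM.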

Compound 4, inhibition constant: 3480 nM
The estimate for compound 4 lay 2.9-fold (0.46 log units) below the measured number; low and high end bracket the measured number.
By their numbers in this assay, from the lowest: compounds 2 and 1 (each within the scatter of the next); then compounds 3 and 4 (each within the scatter of the next).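

Placing 6-methylpyridin-3-yl in place of 4-methylphenyl on a carbonyl carbon gives a 4.5-fold higher number from compound 1 to compound 4 (0.65 log units; beyond the scatter) in this assay and is the first one-place comparison in the series. At this position, a change of one ring carbon to nitrogen, with the heavy-atom count unchanged, is enough to move the number beyond the scatter. No measurement at hand accounts for the loss.

From the compounds shown here alone, whether the ring nitrogen alone carries the step stays open. Unsubstituted pyridin-3-yl, or a methoxy group or an amine in place of the methyl group, would help to separate the contributions.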